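This account rests on a few compounds, and the source may have more. Where it says the series, first, only, none or still open, it means among the compounds named here.

Compound 1 `C=CCN(Cc1ccc2nc(C)[nH]c(=O)c2c1)c1ccc(C(=O)N[C@@H](CCC(=O)O)C(=O)O)cc1F` belongs to a small series built on a shared core carrying a glutamate-bearing benzoyl arm. In an assay on isolated protein for inhibition of Thymidylate synthase (Mus musculus) (a lower number here means a stronger inhibitor, a higher number a weaker inhibitor), compound 1 gives 5160 nM, the higher of the two numbers recorded so far. Among the measured compounds shown here, its only measured companion is compound 2 `CCN(Cc1ccc2nc(C)[nH]c(=O)c2c1)c1ccc(C(=O)N[C@@H](CCC(=O)O)C(=O)O)c(F)c1`, which differs from compound 1 in more than one place, carrying an ethyl on the aromatic nitrogen and its fluorine at a different position of the benzoyl ring; in this assay compound 2 gives 45 nM, a far lower number, placing compound 1 as the weaker of the two by a margin well beyond the scatter. For the measured compounds named here, no single-change step between measured compounds is available to read from.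

The next compound, compound 3 `Cc1nc2ccc(CNc3ccc(C(=O)N[C@@H](CCC(=O)O)C(=O)O)cc3F)cc2c(=O)[nH]1`, changes compound 1 at one place: hydrogen in place of allyl on a nitrogen on an aromatic ring. With nothing measured that isolates such a change, the expectation is cautious: no step beyond the scatter from compound 1 is expected, a 1.1-fold lower number from compound 1 to compound 3 (0.06 log units; within the scatter), because compound 1 already sits at 5160 nM and the ethyl-bearing compound 2 cannot be read as a guide to the nitrogen substituent alone. For compound 3 in this assay the estimate is therefore 4500 nM, with a range from 1200 nM to 18000 nM.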

Compound 3, half-maximal inhibitory concentration: 9340 nM
Compound 3: the middle estimate sits 2.1-fold (0.32 log units) below what was measured; measured number inside the range.
By their numbers in this assay, from the lowest: compound 2; then compounds 1 and 3 (each within the scatter of the next).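

Hydrogen in place of allyl on a nitrogen on an aromatic ring gives a 1.8-fold higher number from compound 1 to compound 3 (0.26 log units; within the scatter) in this assay, the first reading in this series of a single change at this nitrogen. On the core and fluorinated benzoyl arm shared by these two compounds, therefore, the allyl group, with its three carbons and its double bond, can give way to hydrogen without a step that can be told from the scatter, so the two values cannot be put in any order. Nothing measured on these compounds speaks to the reason for this result.

As far as these compounds go, it remains open whether a propargyl group, a hydroxyethyl group or a longer chain on this nitrogen would read the same way on this arm. Among the compounds shown here, also open is how much of the distance between compound 1 and compound 2 belongs to the ethyl group and how much to the position of the fluorine, since those two compounds differ in both places and no single-change step separates them.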